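Bromophenylsulfonyl Replacing Acetylcarbonyl: Outlook for Tolerability

The compounds below may be only part of what the source reports. "The series", "measured", "known", "first", "only" and "open" are said of these compounds alone.

Three compounds sharing one core have been examined in a functional assay on HEK293 cells (Homo sapiens) for cytotoxicity; a higher number here means that more compound is tolerated, a lower number that less compound is tolerated. Compound 1 `COc1ccc([C@H]2CC(=O)N(C(C)=O)C2)cc1OC1CCCC1` gives > 10000 nM in this assay, which is a limit of the assay rather than a number. Compound 2 `COc1ccc([C@H]2CC(=O)N(c3ccc([S+](C)[O-])cc3)C2)cc1OC1CCCC1` gives 7510 nM. Compound 3 `COc1ccc([C@H]2CC(=O)N(c3cccc(NC(=O)C(C)=O)c3)C2)cc1OC1CCCC1` gives > 10000 nM, again a limit and not a number. Both limits are the same one: the limit of > 10000 nM in this assay, at which 2 of the 3 values shown sit. Going by the values given here, the single measured step, an at least 1.3-fold lower number from compound 1 to compound 2 (0.12 log units; that floor lies within the scatter), sits on the amide-type nitrogen in the ring, not at the place altered below, and stays within the scatter.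

Compound 4 `COc1ccc([C@H]2CC(=O)N(c3cccc(NS(=O)(=O)c4cccc(Br)c4)c3)C2)cc1OC1CCCC1` differs from compound 3 in one place: (3-bromophenyl)sulfonyl in place of acetylcarbonyl on a nitrogen on an aromatic ring. Among the compounds with values here, no measured step touches the nitrogen on the aromatic ring, so there is no direct precedent for this change. Within the data shown here, the only quantified step stays within the scatter, and compound 3 itself stands at a limit. On that basis compound 4 is expected to show a step of an at least 1.2-fold lower number from compound 3 to compound 4 (0.09 log units; that floor lies within the scatter), that is, no change beyond the scatter. Compound 4 is accordingly estimated at 8000 nM, with a range from 3000 nM to 20000 nM, and with a real chance that this assay again reports only a limit.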

Compound 4, half-maximal cytotoxic concentration: > 10000 nM
Compound 4: only a limit was reported (the forecaster's own chance of this, stated with the estimate: 55%); middle value at least 1.2-fold (0.09 log units) from the limit.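

Compound 3 and compound 4 both stand at a limit rather than a number in this assay, so no step can be read between them: the limit of > 10000 nM in this assay, at which 3 of the 4 values shown sit.

The compounds shown leave open whether (3-bromophenyl)sulfonyl in place of acetylcarbonyl on a nitrogen on an aromatic ring changes the half-maximal cytotoxic concentration at all, and in which direction.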